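From hydroxy to methoxy on compound 1

The compounds below may be only part of what the source reports. "The series", "measured", "known", "first", "only" and "open" are said of these compounds alone.

In a functional assay on ACHN cells (Homo sapiens) for antiproliferative activity, read by sulforhodamine B assay, with a stated time of 48 h (a lower number here means a stronger inhibitor, a higher number a weaker inhibitor), compound 1 `O=C(NCCCNc1cc(-c2cn(-c3ccccc3)nc2-c2cccc(O)c2)ccn1)Nc1ccc(F)cc1` gives 3160 nM and compound 2 `O=C(NCCCNc1cc(-c2cn(-c3ccccc3)nc2-c2cccc(O)c2)ccn1)Nc1cccc(C(F)(F)F)c1` gives 5240 nM as its value. Among the measured compounds shown here, these are the only two measured numbers, and they stand level with each other, since a 1.7-fold higher number from compound 1 to compound 2 (0.22 log units; within the scatter) lies within the scatter.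

Compound 3 `COc1cccc(-c2nn(-c3ccccc3)cc2-c2ccnc(NCCCNC(=O)Nc3ccc(F)cc3)c2)c1` keeps the core of compound 1 and alters one group, turning 3-hydroxyphenyl into 3-methoxyphenyl. The change, (methyl in place of hydrogen on an oxygen on an aromatic ring), is methyl in place of hydrogen on an oxygen on an aromatic ring.

For the measured compounds named here, no measured pair tests this change directly. Going by the values given here, the one measured step swaps a group on an amide-type nitrogen and leaves the hydroxy group untouched, so it offers only a loose guide: one swap elsewhere on compound 1 stayed within the scatter. The data give no direction for the new change, so no shift beyond the scatter is expected. The estimated step, a 1.2-fold higher number from compound 1 to compound 3 (0.08 log units; within the scatter), is correspondingly small. Compound 3 is expected to give 3800 nM with an estimated range of 1400 nM to 10000 nM as the likely span.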

Compound 3, half-maximal inhibitory concentration: 10600 nM
Compound 3: the middle estimate sits 2.8-fold (0.45 log units) below what was measured, and the stated range ends below it.
By their numbers in this assay, from the lowest: compounds 1 and 2 (each within the scatter of the next); then compound 3.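

In this assay, putting methyl in place of hydrogen on the oxygen gives a 3.4-fold higher number from compound 1 to compound 3 (0.53 log units; beyond the scatter) and so makes a modest but readable difference. Among the compounds shown here, the only earlier step, the swap on the amide-type nitrogen, gave a 1.7-fold higher number from compound 1 to compound 2 (0.22 log units; within the scatter) and stayed within the scatter, so this oxygen on the aromatic ring is the first place in this short series where a one-group change can be told apart from the noise of repeated measurements. The compounds shown offer no independent measurement that could explain the weaker result for compound 3.

Compounds with an amine or an ethoxy group in the place of the hydroxy group would help show whether the loss follows the missing hydrogen on the oxygen or the added carbon, a question that one pair cannot settle. From the compounds shown here alone, it also remains open whether the same change would produce a step of similar size on compound 2, which carries the 3-(trifluoromethyl)phenyl group instead of the 4-fluorophenyl group.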